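This account rests on a few compounds, and the source may have more. Where it says the series, first, only, none or still open, it means among the compounds named here.

Measured compounds:
compound 1, `CC(=O)O[C@@H]1C=CC(=O)O[C@@H]1[C@@H](COC(=O)c1ccc([N+](=O)[O-])cc1)OC(C)=O`, gives 5320 nM in a functional assay on MCF7 cells (Homo sapiens) for antiproliferative activity, read by MTT assay, with a stated time of 6 days; a lower number here means a stronger inhibitor, a higher number a weaker inhibitor;
compound 2, `O=C1C=C[C@@H](OCc2ccccc2)[C@@H]([C@@H](COC(=O)/C=C/c2ccccc2)OCc2ccccc2)O1`, gives 2570 nM in this assay.

Among these two numbers, compound 2 stands at the lower end, and compound 1 sits above it by a margin that lies beyond the usual scatter of repeated measurements. The two compounds differ in several places at once, so their values alone do not say which of those differences carries the gap.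

Compound 3, `O=C1C=C[C@@H](OCc2ccccc2)[C@@H]([C@@H](COC(=O)/C=C/c2ccc([N+](=O)[O-])cc2)OCc2ccccc2)O1`, is the next compound to be measured in this assay. It differs from compound 2 in one place only: nitro in place of hydrogen on an aromatic carbon. Among the measured compounds shown here, no pair of measured compounds differs by this change alone, so there is no measured step to lean on. The account of compound 2 is therefore the only anchor, and the step from compound 2 to compound 3 is expected to be small, a 1.1-fold lower number from compound 2 to compound 3 (0.03 log units; within the scatter), in neither direction beyond the scatter. For compound 3 the estimate in this assay is 2400 nM, with a range from 900 nM to 6500 nM.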

Compound 3, half-maximal inhibitory concentration: 1660 nM
For compound 3 the middle estimate is 1.4-fold (0.16 log units) above the measured one; measured number inside the range.
By their numbers in this assay, from the lowest: compounds 3 and 2 (each within the scatter of the next); then compound 1.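

Nitro in place of hydrogen on an aromatic carbon, para to a large group, can now be read directly in this assay as a single change: a 1.5-fold lower number from compound 2 to compound 3 (0.19 log units; within the scatter). This step stays within the scatter, so at this position of the 2-phenylethenyl group the nitro group leaves the number indistinguishable from that of the unsubstituted phenyl, and compound 2 and compound 3 cannot be ranked against each other. Nothing shown bears on why the step has this size.

Going by these compounds, a single substituent does not map the position, so it remains open whether an amine, a methoxy group or a carboxylic acid on the same aromatic carbon would also stay within the scatter or would move the number beyond it. Also open, on these data alone, is what separates compound 1 from the other two compounds, since it carries a nitro group too but differs from them in several places at once, and how a longer chain in place of the 2-phenylethenyl group would read.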